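Swapping methoxy for trifluoromethyl on the pendant phenyl ring

This account rests on a few compounds, and the source may have more. Where it says the series, first, only, none or still open, it means among the compounds named here.

Compound 1: `CN(C)CCCCOC(=O)Nc1ccc(Cn2nc(-c3ccc(C(F)(F)F)cc3)c3ccccc3c2=O)cc1` — 3360 nM
Compound 2: `COc1ccccc1-c1nn(Cc2ccc(NC(=O)OCCCCN(C)C)cc2)c(=O)c2ccccc12` — 44800 nM

Within the data shown here, in an ADME assay on Huh-7 cells (Homo sapiens) for cytotoxicity, read by MTT assay, with a stated time of 48 h (a lower number here means that less compound is tolerated, a higher number that more compound is tolerated), compound 2 gives the higher of the two numbers so far, and compound 1 gives the lower. The step of a 13-fold higher number from compound 1 to compound 2 (1.12 log units; beyond the scatter) is large. Compound 3, `CN(C)CCCCOC(=O)Nc1ccc(Cn2nc(-c3ccccc3C(F)(F)F)c3ccccc3c2=O)cc1`, differs from compound 2 by trifluoromethyl in place of methoxy on an aromatic carbon. This reverses the group exchange that produced the large step from compound 1 to compound 2, though at a different position on the same ring, so a lower number is expected for compound 3, likely a step of about a 4.5-fold lower number from compound 2 to compound 3 (0.65 log units; beyond the scatter). The expected value for compound 3 in this assay is 10000 nM, between 3000 nM and 35000 nM.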

Compound 3, half-maximal cytotoxic concentration: 35700 nM
Compound 3: middle estimate off by 3.6-fold (0.55 log units), on the low side; the measured number lies above the stated range.
By their numbers in this assay, from the lowest: compound 1; then compounds 3 and 2 (each within the scatter of the next).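

In this assay the exchange at this place, ortho to a large group, is a 1.3-fold lower number from compound 2 to compound 3 (0.10 log units; within the scatter) and so leaves methoxy and trifluoromethyl within the usual scatter of each other. Keeping trifluoromethyl, 2-(trifluoromethyl)phenyl in place of 4-(trifluoromethyl)phenyl is an 11-fold higher number from compound 1 to compound 3 (1.03 log units; beyond the scatter) and counts as large, so among these three compounds the number follows where the group sits, not which of the two groups it is. Nothing available here explains why the place matters. As far as these compounds go, whether a chlorine atom or an amine in that same place would give a similar number remains open.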